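The source may hold more compounds than are shown below. What is called first, only, known or untested is meant among the compounds shown, and "the series" means these compounds.

Measured compounds:
- Compound 1 `CCCCN(CCCC)CCCOc1ccc(S(=O)(=O)c2c(-c3ccccc3)cn3ccccc23)cc1`: 1620 nM
- Compound 2 `CCCCN(CCCC)CCCOc1ccc(S(=O)(=O)c2c(C)cn3ccccc23)cc1`: 162 nM

In a functional assay (aorta) with Rattus norvegicus as the target (a lower number here means a stronger inhibitor, a higher number a weaker inhibitor), compound 2 has the lower of the two numbers, at 162 nM, making it the stronger inhibitor so far. Compound 3 `CCCCN(CCCC)CCCOc1ccc(S(=O)(=O)c2c(CCC)cn3ccccc23)cc1` keeps the core of compound 2 but turns its methyl into propyl, with ethyl in place of hydrogen on a saturated chain carbon bound to an aromatic carbon. For the measured compounds named here, only one measured step bears on this group: a 10-fold lower number from compound 1 to compound 2 (1.00 log units; beyond the scatter). That step shows that a change here can move the number, but it swaps phenyl for methyl, which is a different change. No chain longer than methyl has been measured. With compound 1 at 1620 nM as the only other reference point, a small rise is expected, though its direction is uncertain. The expected step is a 1.2-fold higher number from compound 2 to compound 3 (0.09 log units; within the scatter). For compound 3 the estimate is 200 nM, with an expected range of 70 nM to 650 nM.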

Compound 3, half-maximal inhibitory concentration: 54.3 nM
Compound 3: the middle estimate sits 3.7-fold (0.57 log units) above what was measured, and the stated range ends above it.
By their numbers in this assay, from the lowest: compound 3; then compound 2; then compound 1.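

In this assay, turning methyl into propyl on this aromatic carbon gives a 3.0-fold lower number from compound 2 to compound 3 (0.47 log units; beyond the scatter) and so shows that the length of a saturated chain here affects the number by itself, which the swap of phenyl for methyl could not show. Replacing phenyl with propyl gives a 30-fold lower number from compound 1 to compound 3 (1.47 log units; beyond the scatter) and is the largest step among these compounds, placing propyl ahead of both methyl and phenyl at this position. Nothing available explains why the longer chain gives the lower number.

The compounds shown carry only phenyl, methyl and propyl here, so it remains open whether a butyl or longer chain would lower the number further or raise it again. Going by these compounds, whether a branched isopropyl group or a chain ending in an amine would do as well also remains open.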